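The source may report more compounds than this note shows. Statements on the series, on what has been measured and on what is new or still open speak of the compounds shown alone.

In a functional assay on KB cells (Homo sapiens) for inhibition, read by sulforhodamine B assay, with a stated time of 72 h (a lower number here means a stronger inhibitor, a higher number a weaker inhibitor), compound 1 `C[C@H](OC(=O)/C=C\c1ccc(O)cc1)[C@@H]1CC[C@H]([C@H](O)[C@H]2CC=CC(=O)O2)O1` gives 7500 nM and compound 2 `C[C@H](OC(=O)/C=C/c1ccc(O)cc1)[C@@H]1CC[C@H]([C@H](O)[C@H]2CC=CC(=O)O2)O1` gives 3600 nM as the lower of the two numbers. For the measured compounds named here, the one measured step is a 2.1-fold lower number from compound 1 to compound 2 (0.32 log units; beyond the scatter) and it is modest; it comes with the fact that compounds 1 and 2 differ only in the configuration as drawn and so involves no ring substituent. Compound 3 `C[C@H](OC(=O)/C=C/c1ccc(O)c(O)c1)[C@@H]1CC[C@H]([C@H](O)[C@H]2CC=CC(=O)O2)O1` departs from compound 2 by hydroxy in place of hydrogen on an aromatic carbon in the form of hydroxy in place of hydrogen on an aromatic carbon, 4-hydroxyphenyl to 3,4-dihydroxyphenyl. Going by the values given here, with compound 2 at 3600 nM as the anchor and no measured step covering such a change, no shift beyond the scatter is expected in this assay and neither direction is favoured. Compound 3 is estimated at 3000 nM within an expected range of 1000 nM to 9000 nM for now.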

Compound 3, half-maximal inhibitory concentration: 4900 nM
Compound 3: middle estimate off by 1.6-fold (0.21 log units), on the low side; the measured number falls inside the stated range.
By their numbers in this assay, from the lowest: compounds 2, 3 and 1 (each within the scatter of the next, the first and the last beyond it).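

Hydroxy in place of hydrogen on the aromatic carbon, 4-hydroxyphenyl to 3,4-dihydroxyphenyl, gives a 1.4-fold higher number from compound 2 to compound 3 (0.13 log units; within the scatter) in this assay. This position, ortho to a hydroxy group and meta to a large group, therefore accepts a hydroxy group without a change beyond the scatter, whereas the earlier pair spoke only to double-bond configuration. Nothing measured here bears on why this step is so small.

From the compounds shown here alone, whether methoxy, an amine or a carboxylic acid at this position would behave the same stays open. So does the effect of the added hydroxy on the Z double-bond form, compound 1.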